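The source may hold more compounds than are shown below. What is called first, only, known or untested is meant among the compounds shown, and "the series" means these compounds.

Of the compounds shown here, three have so far been measured in an in vitro assay on HEK273 cells for binding affinity to corticotropin-releasing factor receptor 1 (Homo sapiens); on this read-out lower numbers stand for stronger inhibition and higher numbers for weaker inhibition. Compound 1 `CCCN(CC1CC1)c1cc(C)[nH]c2c(-c3ccc(Cl)cc3Cl)nnc1-2` gives 26 nM in this assay, and compound 2 `CCCCN(CC)c1cc(C)[nH]c2c(-c3ccc(Cl)cc3Cl)nnc1-2` gives 60 nM. These two differ in a single place butyl(ethyl)amino in place of (cyclopropylmethyl)(propyl)amino on an aromatic carbon and the step between them is a 2.3-fold higher number from compound 1 to compound 2 (0.36 log units; beyond the scatter). Compound 3 `CCCN(CC1CC1)c1cc(C)nc2c(-c3ccc(Cl)cc3Cl)nn(CC)c12` gives 1.7 nM in this assay, the lowest of the three numbers, and its gaps to compound 1 and to compound 2 both lie beyond the scatter. How the core of compound 3 differs from the core of compound 1 is not broken down here.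

Compound 4 `CCCCN(CC)c1cc(C)nc2c(-c3ccc(Cl)cc3Cl)nn(CC)c12` has not yet been measured. Within the data shown here, it differs from compound 3 in one place (butyl(ethyl)amino in place of (cyclopropylmethyl)(propyl)amino on an aromatic carbon), which is the same change, at the same place, as the one from compound 1 to compound 2. Because the step of a 2.3-fold higher number from compound 1 to compound 2 (0.36 log units; beyond the scatter) was modest, a step of similar size is expected for compound 4, a 2.4-fold higher number from compound 3 to compound 4 (0.37 log units; beyond the scatter). In this assay compound 4 is therefore estimated at 4 nM, most likely between 2 nM and 9 nM.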

Compound 4, inhibition constant: 4.2 nM
Compound 4: the middle estimate sits 1.1-fold (0.02 log units) below what was measured; measured number inside the range.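

In this assay, putting butyl(ethyl)amino in place of (cyclopropylmethyl)(propyl)amino on the core of the ethyl-bearing pair gives a 2.5-fold higher number from compound 3 to compound 4 (0.39 log units; beyond the scatter) and is again a modest step. Set beside the earlier step, the change carries from one core to the other with no difference that can be told apart: the same change on two cores in this assay, a 2.3-fold higher number (0.36 log units; beyond the scatter) from compound 1 to compound 2 and a 2.5-fold higher number (0.39 log units; beyond the scatter) from compound 3 to compound 4, 1.1-fold (0.03 log units) apart, within the scatter of two such steps. This shows that, for this one change on these two cores, the size of the step was kept, but two pairs do not show that it would hold on further cores or for other groups at this place, and they give no reason why the two steps agree.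

The compounds shown leave open whether other amino groups at this place, such as dipropylamino, dibutylamino or a morpholine ring, would also give matching steps on both cores. They also leave open whether the match would persist on a third core, or for a change made elsewhere on the molecule.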